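A Cyano Group Added to Two Different Cores

A few compounds are considered here, and "the series" means these few. Any claim that something is new, unique, unknown or untested is made for them only; others in the source may bear on it.

Compound 1 `O=C(NCc1ccc(OCc2ccccc2)cc1)n1cccn1` gives 800 nM in an assay on membranes from brain for binding affinity to Fatty-acid amide hydrolase 1 (Mus musculus), read by fluorescence, with stated times of 1 h and 30 min; on this read-out lower numbers stand for stronger inhibition and higher numbers for weaker inhibition.
Compound 2 `N#Cc1cnn(C(=O)NCc2ccc(OCc3ccccc3)cc2)c1` gives 60 nM in this assay.
Compound 3 `CN(CCN(C)C(c1ccc(OCc2ccccc2)cc1)c1ccc(OCc2ccccc2)cc1)C(=O)n1cccn1` reaches only the limit of this assay, > 1000000 nM.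

Compound 1 and compound 2 share a core and differ by one change, (cyano in place of hydrogen on an aromatic carbon), which gave a 13-fold lower number from compound 1 to compound 2 (1.12 log units; beyond the scatter). Compound 3 has a different core; the difference between the two cores is not broken down here. For compound 3 the assay gives no number, only a limit (the limit of > 1000000 nM in this assay, at which 1 of the 3 values shown sits).

Compound 4 `CN(CCN(C)C(c1ccc(OCc2ccccc2)cc1)c1ccc(OCc2ccccc2)cc1)C(=O)n1cc(C#N)cn1` is compound 3 with the same change, (cyano in place of hydrogen on an aromatic carbon). The place of the change reads the same as for compound 1 and compound 2, so the change is the same. Going by the values given here, because compound 3 sits at the limit (the limit of > 1000000 nM in this assay, at which 1 of the 3 values shown sits), no measured step can be built from it, and the earlier step of a 13-fold lower number from compound 1 to compound 2 (1.12 log units; beyond the scatter) is the only guide; the expected step is an at least 3.3-fold lower number from compound 3 to compound 4 (0.52 log units; beyond the scatter), with most of the chance that compound 4 also returns only a limit. Compound 4 is therefore estimated at 300000 nM, between 30000 nM and 1000000 nM.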

Compound 4, half-maximal inhibitory concentration: > 1000000 nM
Compound 4 was reported as a limit (the forecaster's own chance of this, stated with the estimate: 75%); middle value at least 3.3-fold (0.52 log units) away from the limit.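

Compound 4 returns only a limit in this assay, > 1000000 nM. No step can be read from compound 3 to compound 4, because both compounds stand at the same limit: the limit of > 1000000 nM in this assay, at which 2 of the 4 values shown sit.

The compounds shown leave open how strongly either one truly inhibits, and whether adding cyano has any effect on the core of compound 3.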